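The source may hold more compounds than are shown below. What is called first, only, known or untested is meant among the compounds shown, and "the series" means these compounds.

In a functional assay on A549 cells (Homo sapiens) for inhibition, read by MTT assay, with a stated time of 72 h (on this read-out lower numbers stand for stronger inhibition and higher numbers for weaker inhibition), compound 1 `O=C(Nc1ccccc1)C1CCN(C/C=C/c2ccccc2)CC1` gives 69700 nM, which puts it at the high end of the numbers, within the scatter of compound 3 `COc1ccc(NC(=O)C2CCN(C/C=C/c3ccccc3)CC2)cc1` at 83800 nM. Compound 2 `CCCCc1ccc(NC(=O)C2CCN(C/C=C/c3ccccc3)CC2)cc1` has the lowest number, 5910 nM. Compound 4 `O=C(Nc1cccc(C(F)(F)F)c1)C1CCN(C/C=C/c2ccccc2)CC1` differs from compound 1 in one place: trifluoromethyl in place of hydrogen on an aromatic carbon. Two measured steps also replace a hydrogen on an aromatic carbon. With butyl there is a large step, a 12-fold lower number from compound 1 to compound 2 (1.07 log units; beyond the scatter), and with methoxy the step stays within the scatter, a 1.2-fold higher number from compound 1 to compound 3 (0.08 log units; within the scatter). Trifluoromethyl is neither group, so a modest move toward a lower number in this assay is expected, an estimated 2.3-fold lower number from compound 1 to compound 4 (0.37 log units; beyond the scatter). For compound 4 the estimated value is 30000 nM, with an expected range from 10000 nM to 80000 nM.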

Compound 4, half-maximal inhibitory concentration: 15600 nM
Estimate against measurement, compound 4: 1.9-fold (0.28 log units) above; the measured number falls inside the stated range.
By their numbers in this assay, from the lowest: compound 2; then compound 4; then compounds 1 and 3 (each within the scatter of the next).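

In this assay trifluoromethyl, meta to a large group, gives a 4.5-fold lower number from compound 1 to compound 4 (0.65 log units; beyond the scatter). Butyl is therefore not the only replacement for a hydrogen on this aromatic ring that moves the number beyond the scatter, although this modest step is smaller than the large one with butyl, a 12-fold lower number from compound 1 to compound 2 (1.07 log units; beyond the scatter). Unlike methoxy, trifluoromethyl leaves compound 4 clearly lower than compound 1.

From the compounds shown here alone, whether an amine or a carboxylic acid at this same place would also lower the number remains open. No measurement shown explains the trifluoromethyl step.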